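This account rests on a few compounds, and the source may have more. Where it says the series, first, only, none or still open, it means among the compounds named here.

Compound 3 `O=C(Nc1ccc(C(=O)O)c(O)c1)c1ccc(N2C(=O)CCS2(=O)=O)cc1` stands highest of the three numbers in an assay on isolated protein for inhibition of NAD-dependent protein deacylase sirtuin-6 (Homo sapiens), read by fluorescence, tested at 200 uM (a lower number here means less inhibition, a higher number more inhibition at the concentration tested (going by the name of the read-out)), where compound 3 gives 100%. Compound 1 `O=C(Nc1ccc(O)c(C(=O)O)c1)c1ccc(N2C(=O)CCS2(=O)=O)cc1` gives 89% in this assay, and compound 2 `CCC(=O)Nc1ccc(C(=O)Nc2ccc(C(=O)O)c(O)c2)cc1` gives 70%. Within the data shown here, the only measured step, a number 30 percentage points higher from compound 2 to compound 3 (beyond the scatter), brought in the very group that now leaves. Compound 4 `O=C(Nc1ccc(C(=O)O)c(O)c1)c1ccc(NC(=O)c2ccco2)cc1` differs from compound 3 by a group of 8 heavy atoms (5 carbon, 1 nitrogen, 2 oxygen; one five-membered aromatic ring with 1 hetero atom) in place of a group of 8 heavy atoms (3 carbon, 1 nitrogen, 3 oxygen, 1 sulfur; one five-membered non-aromatic ring with 2 hetero atoms), on an aromatic carbon. The entering group, like the propanoylamino of compound 2, carries one hydrogen-bond donor and no non-aromatic ring, so the step measured from compound 2 to compound 3 is the one that bears on it, and a move back in the other direction is expected, of roughly that size. Compound 4 is therefore estimated at 72%, range 52% to 92%, a step of a number 28 percentage points lower from compound 3 to compound 4 (beyond the scatter).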

Compound 4, a percentage reported as inhibition, at one concentration (the size of the read-out at that concentration, not a potency): 100%
Compound 4: the middle estimate sits 28 percentage points below what was measured; measured number above the stated range.
By their numbers in this assay, from the lowest: compound 2; then compound 1; then compounds 3 and 4 (each within the scatter of the next).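

In this assay the exchange gives no change at the digits printed from compound 3 to compound 4 (within the scatter), so at this position the five-membered non-aromatic ring with its sulfur is not required to keep the read-out at the level of compound 3. On the amide carbonyl carbon, furan-2-yl in place of ethyl gives a number 30 percentage points higher from compound 2 to compound 4 (beyond the scatter), a step of the same printed size as a number 30 percentage points higher from compound 2 to compound 3 (beyond the scatter). No measurement here bears on the cause.

A single tested concentration leaves compound 3 and compound 4 unseparated. From the compounds shown here alone, whether phenyl, cyclopropyl or a longer chain on that carbonyl carbon would serve as furan-2-yl does remains open.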